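This account rests on a few compounds, and the source may have more. Where it says the series, first, only, none or still open, it means among the compounds named here.

Measured compounds:
compound 1 `O=C(/C=C/c1ccc2c(c1)B(O)OC2)c1ccco1`, 20700 nM
compound 2 `O=C(/C=C/c1ccc2c(c1)B(O)OC2)c1cccnc1`, 18500 nM
compound 3 `CSc1ccc(C(=O)/C=C/c2ccc3c(c2)B(O)OC3)cc1`, 4100 nM

All three share one core and differ only in the group attached to the carbonyl carbon. In a functional assay on SK-OV-3 cells (Homo sapiens) for cytotoxicity, read by MTT assay, with a stated time of 48 h (on this read-out higher numbers stand for weaker inhibition and lower numbers for stronger inhibition), compound 1 gives 20700 nM, which sits at the high end of the three numbers; compound 2 gives 18500 nM, a value within the scatter of it, while compound 3 gives 4100 nM, a number well below. Compound 4 `O=C(/C=C/c1ccc2c(c1)B(O)OC2)c1cccc(F)c1` is not yet measured and differs from compound 1 in one place: 3-fluorophenyl in place of furan-2-yl on a carbonyl carbon. For the measured compounds named here, the only measured step at this position, a 1.1-fold lower number from compound 1 to compound 2 (0.05 log units; within the scatter), exchanges one ring containing a hetero atom for another and shows no change beyond the scatter. Compound 3, however, also carries a six-membered carbon-only ring on the carbonyl carbon, and its value lies well below that of compound 1. A moderate drop in number is therefore expected for compound 4: a 2.3-fold lower number from compound 1 to compound 4 (0.36 log units; beyond the scatter). The estimate for compound 4 in this assay is 9000 nM, with a range from 3500 nM to 23000 nM.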

Compound 4, half-maximal inhibitory concentration: 4800 nM
Estimate against measurement, compound 4: 1.9-fold (0.27 log units) above, and the stated range covers the measured number.
By their numbers in this assay, from the lowest: compounds 3 and 4 (each within the scatter of the next); then compounds 2 and 1 (each within the scatter of the next).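

Putting 3-fluorophenyl on the carbonyl carbon gives a change beyond the scatter, which the swap between the two hetero-atom rings did not: a 4.3-fold lower number from compound 1 to compound 4 (0.63 log units; beyond the scatter) in this assay, and a 3.9-fold lower number from compound 2 to compound 4 (0.59 log units; beyond the scatter). Compound 1 and compound 2 lie within the scatter of each other, as do compound 3 and compound 4, so among these four the two compounds with a carbon-only ring give the lower numbers, and none goes against this. No measurement shown here explains this difference between the rings.

The compounds shown leave open how much of the change belongs to the fluorine and how much to the ring itself, as an unsubstituted phenyl group is not among them. Also open, from the compounds shown here alone, is what a ring carrying an amine or a carboxylic acid, or a saturated cyclohexyl group, would give at this place.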